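Removing one methoxy from the aryl ketone of compound 2

The compounds below may be only part of what the source reports. "The series", "measured", "known", "first", "only" and "open" are said of these compounds alone.

Compound 1 `COc1cc(-c2cc(/C=C/C(=O)c3ccc(N)cc3)[nH]n2)cc(OC)c1OC` and compound 2 `COc1ccc(C(=O)/C=C/c2cc(-c3cc(OC)c(OC)c(OC)c3)n[nH]2)cc1OC` share the same core and differ only in the aryl group on the carbonyl carbon. In a functional assay on RPMI-8226 cells (Homo sapiens) for inhibition, read by sulforhodamine B assay, with a stated time of 48 h (a lower number here means a stronger inhibitor of growth, a higher number a weaker inhibitor of growth), compound 1 gives 470 nM, and compound 2 gives 240 nM. Within the data shown here, the single measured step, a 2.0-fold lower number from compound 1 to compound 2 (0.29 log units; within the scatter), stays within the scatter, so compound 2 holds the lower of the two numbers without standing apart from compound 1.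

Compound 3 `COc1ccc(C(=O)/C=C/c2cc(-c3cc(OC)c(OC)c(OC)c3)n[nH]2)cc1` carries the change (hydrogen in place of methoxy on an aromatic carbon); cut one bond further out, this reads 3,4-dimethoxyphenyl to 4-methoxyphenyl. Among the measured compounds shown here, no measured step removes a methoxy; the one step that alters this ring, a 2.0-fold lower number from compound 1 to compound 2 (0.29 log units; within the scatter), lay within the scatter. Compound 3 is therefore expected to land close to compound 2, with an estimated step of a 1.3-fold higher number from compound 2 to compound 3 (0.12 log units; within the scatter) that should not exceed the scatter. For compound 3 the estimate in this assay is 320 nM, with a range from 110 nM to 950 nM.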

Compound 3, concentration for 50% growth inhibition: 430 nM
Compound 3: the middle estimate sits 1.3-fold (0.13 log units) below what was measured, within the range that was stated.
By their numbers in this assay, from the lowest: compounds 2, 3 and 1 (each within the scatter of the next).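

In this assay, the earlier step replaced the whole aryl group on the carbonyl carbon, whereas this one isolates a single methoxy, ortho to a methoxy group and meta to a large group. Its exchange for hydrogen gives a 1.8-fold higher number from compound 2 to compound 3 (0.25 log units; within the scatter), so this methoxy is not shown to matter for growth inhibition, and the exchange of amino for methoxy on the aromatic carbon, a 1.1-fold lower number from compound 1 to compound 3 (0.04 log units; within the scatter), likewise leaves the number within the scatter. No supporting measurement is available to explain why these three aryl ketones read so closely.

As far as these compounds go, what remains open is whether any group on this carbon can move the number beyond the scatter, such as a hydroxyl, a fluorine or an ethoxy. From the compounds shown here alone, it is also open what a plain phenyl, carrying neither methoxy, would give.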